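Replacing the methoxyphenyl arm on a nucleoside-like series

This account rests on a few compounds, and the source may have more. Where it says the series, first, only, none or still open, it means among the compounds named here.

Measured so far:
- compound 1 `C=CCn1c(=O)n(Cc2ccccc2)c2nc(N)nc(O)c21`: 25%
- compound 2 `COc1ccc(Cn2c(=O)n(C3OC(CO)[C@@H](O)[C@H]3O)c3nc(N)nc(O)c32)cc1`: 44%
- compound 3 `CC1(C)O[C@@H]2[C@H](O1)[C@@H](CO)O[C@H]2n1c(=O)n(C/C=C/c2ccccc2)c2c(O)nc(N)nc21`: 16%

In a functional assay on the whole organism (B cells) with Mus musculus as the target (on this read-out higher numbers stand for larger maximal responses and lower numbers for smaller maximal responses), compound 2 gives the highest of the three numbers; compound 1 sits closer to it, compound 3 furthest away, both beyond the scatter. The unmeasured compound 4 `Nc1nc(O)c2c(n1)n(C1OC(CO)[C@@H](O)[C@H]1O)c(=O)n2C/C=C/c1ccccc1` is built from compound 2 by one change: 2-phenylethenyl in place of 4-methoxyphenyl on a saturated chain carbon bound to an aromatic nitrogen. Going by the values given here, no step between measured compounds isolates this change. Compound 3, which carries the same 2-phenylethenyl-bearing chain on a different sugar, gives 16% in this assay, so a drop beyond the scatter is expected for the step of a number 16 percentage points lower from compound 2 to compound 4 (beyond the scatter). Compound 4 is therefore estimated at 28%, within 12% to 46%.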

Compound 4, largest response reached (reported as maximal response), in percent of the reference or control that the assay uses: 73%
For compound 4 the middle estimate is 45 percentage points below the measured one; measured number outside the range, above it.
By their numbers in this assay, from the lowest: compounds 3 and 1 (each within the scatter of the next); then compound 2; then compound 4.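

In this assay, 2-phenylethenyl in place of 4-methoxyphenyl on a saturated chain carbon bound to an aromatic nitrogen gives a number 29 percentage points higher from compound 2 to compound 4 (beyond the scatter). Going by these compounds alone, this is the first step isolated at this position, and it shows that with the sugar held constant, the change of arm alone moves the response upward. Nothing shown here explains the rise.

The compounds shown do not separate the part played by the double bond from that of the lost methoxy oxygen. From the compounds shown here alone, how an amine or a carboxylic acid on this arm would read also remains open.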